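The compounds below may be only part of what the source reports. "The series", "measured", "known", "first", "only" and "open" are said of these compounds alone.

Going by the values given here, compound 1 `COc1ccc(-c2nc3sc(Cc4ccccc4)nn3c2SC#N)cc1` is the weaker of the two compounds measured so far: in a functional assay on cells (Cancer cell lines, Homo sapiens) for inhibition (on this read-out lower numbers stand for stronger inhibition of growth and higher numbers for weaker inhibition of growth), compound 1 gives 61700 nM, the highest of the two numbers. Compound 2 `Clc1ccc(-c2cn3nc(Cc4ccccc4)sc3n2)cc1`, built on a different core, gives 5300 nM in this assay, a lower number by a gap beyond the usual scatter. Compound 3 `N#CSc1c(-c2ccccc2)nc2sc(Cc3ccccc3)nn12` keeps the core of compound 1 and differs in one place: hydrogen in place of methoxy on an aromatic carbon. Among the compounds with values here, no measured pair shows such a change, so the expected step from compound 1 to compound 3 is small, a 1.4-fold lower number from compound 1 to compound 3 (0.14 log units; within the scatter), and may not clear the scatter. For compound 3 the estimated value is 45000 nM, within 15000 nM to 120000 nM.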

Compound 3, concentration for total growth inhibition: 91200 nM
Beside the measured number, compound 3's estimate is 2.0-fold (0.31 log units) below it; measured number inside the range.
By their numbers in this assay, from the lowest: compound 2; then compounds 1 and 3 (each within the scatter of the next).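

Going from 4-methoxyphenyl to phenyl gives a 1.5-fold higher number from compound 1 to compound 3 (0.17 log units; within the scatter) in this assay, so on this one pair, methoxy and hydrogen cannot be told apart at this place on the ring. The change takes away a hydrogen-bond acceptor and two heavy atoms, yet the read-out shows no clear response to it. Nothing available explains this result.

From the compounds shown here alone, whether an amine or a carboxylic acid at this place would give a number clearly apart from these remains open. A single pair also cannot show whether the same change would behave alike on another core.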